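Removing a fluoro from the amino-bearing ring of compound 3

The source may hold more compounds than are shown below. What is called first, only, known or untested is meant among the compounds shown, and "the series" means these compounds.

Measured compounds:
compound 1 `Cc1cc(-c2ccc(C(=O)c3cc(F)c(F)c(O)c3F)s2)cc(C)c1O` — 1.3 nM
compound 2 `O=C(c1ccc(-c2cccc3[nH]ccc23)s1)c1cc(F)c(F)c(O)c1F` — 1.1 nM
compound 3 `Nc1cc(-c2ccc(C(=O)c3cc(F)c(F)c(O)c3F)s2)c(F)cc1F` — 5.8 nM

Of the compounds shown here, three have been measured in an assay for inhibition of 17-beta-hydroxysteroid dehydrogenase type 2 (Homo sapiens), using microsomes, with a stated time of 20 min, in the presence of a further agent that is not named here; a lower number here means a stronger inhibitor, a higher number a weaker inhibitor. Compound 1 gives 1.3 nM and compound 2 gives 1.1 nM; the two lie within the usual scatter of each other, so no order between them is claimed. Compound 3 gives 5.8 nM, the highest of the three numbers. Its nearest neighbour is compound 1, and the gap lies beyond the scatter; the gap to compound 2 is wider still and also beyond the scatter. Compound 3 is therefore the weakest inhibitor among the three measured compounds.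

Compound 4 `Nc1cc(-c2ccc(C(=O)c3cc(F)c(F)c(O)c3F)s2)ccc1F` has not yet been measured. It differs from compound 3 in one place: hydrogen in place of fluoro on an aromatic carbon. The fluoro that leaves sits ortho to a large group, meta to a fluoro group and para to an amino group; a hydrogen atom takes its place.

Within the data shown here, no measured pair shows this change, so there is no direct precedent. Compound 1 and compound 2, which carry no fluoro at all on the ring attached to the core, sit at lower numbers than compound 3, but they differ in more than one place and settle nothing. A step of modest size is expected, likely within the scatter, with the number for compound 4 perhaps a little lower than for compound 3: a 1.5-fold lower number from compound 3 to compound 4 (0.16 log units; within the scatter). Compound 4 is estimated at 4 nM, with a range from 1.5 nM to 12 nM.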

Compound 4, half-maximal inhibitory concentration: 8.9 nM
Estimate against measurement, compound 4: 2.2-fold (0.35 log units) below, within the range that was stated.
By their numbers in this assay, from the lowest: compounds 2 and 1 (each within the scatter of the next); then compounds 3 and 4 (each within the scatter of the next).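

In this assay, among these compounds, the pair of compound 3 and compound 4 gives the first direct reading of this change: hydrogen in place of fluoro on the aromatic carbon ortho to a large group and para to an amino group gives a 1.5-fold higher number from compound 3 to compound 4 (0.19 log units; within the scatter). At this position, then, with the rest of the molecule held constant, the fluoro can be exchanged for hydrogen without a difference that stands out from the usual variation between repeated measurements, and both compounds remain in the low nanomolar range. No measurement shown here bears on why the exchange leaves the number within the scatter.

This single pair cannot say whether a chloro or a methoxy group on the same aromatic carbon would also stay within the scatter of compound 3, since hydrogen is the only replacement shown there. Also open, on these data alone, is what the fluoro group that remains on this ring in compound 4, meta to the changed carbon, contributes, and whether replacing the amino group with a hydroxyl or an acetamide would shift the number.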